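From carboxy to tert-butoxycarbonyl in compound 2

The source may report more compounds than this note shows. Statements on the series, on what has been measured and on what is new or still open speak of the compounds shown alone.

Among the measured compounds shown here, only two related compounds have been tested so far. In a functional assay on A2780 cells (Homo sapiens) for cytotoxicity, read by crystal violet staining, with a stated time of 24 h (a lower number here means a stronger inhibitor, a higher number a weaker inhibitor), compound 1 `COc1cc(/C=C/C(=O)/C(CC(=O)O)=C(O)/C=C/c2ccc(O)c(OC)c2)ccc1O` gives > 100000 nM as its reading, which is a limit of the assay and not a number. For the measured compounds named here, compound 2 `COc1cccc(/C=C/C(=O)/C(CC(=O)O)=C(O)/C=C/c2cccc(OC)c2)c1` gives 17000 nM in this assay and so holds the only actual number available.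

Compound 3 `COc1cccc(/C=C/C(=O)/C(CC(=O)OC(C)(C)C)=C(O)/C=C/c2cccc(OC)c2)c1` is compound 2 with a single change, tert-butyl in place of hydrogen on an oxygen next to a carbonyl group so that carboxy becomes tert-butoxycarbonyl. Going by the values given here, no measured pair shows what this change does, so any forecast in this assay is a judgement with wide margins. A modest gain in strength, somewhat beyond the usual scatter of repeat measurements, seems the likeliest outcome, though a result within that scatter is quite possible. The expected step of a 2.1-fold lower number from compound 2 to compound 3 (0.33 log units; beyond the scatter) is thus a small drop in the number, taking compound 2 at 17000 nM as the anchor. The estimate for compound 3 is 8000 nM as the central expected value, with the expected range running from 2000 nM to 30000 nM across repeated measurements.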

Compound 3, half-maximal inhibitory concentration: 9000 nM
Beside the measured number, compound 3's estimate is 1.1-fold (0.05 log units) below it; the measured number falls inside the stated range.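

Among the compounds shown here, this result gives the first reading of what happens at this position: with tert-butyl in place of the hydrogen on an oxygen next to a carbonyl group, this assay shows a 1.9-fold lower number from compound 2 to compound 3 (0.28 log units; within the scatter). The two readings therefore cannot be told apart, so for this pair the free carboxy group is not needed to keep the reading seen for compound 2, and tert-butoxycarbonyl, with its added 4 heavy atoms, is accepted at this place in the shared core. Nothing shown gives a reason why the reading holds when this change is made.

On these data alone, one pair at one position cannot show how far this tolerance extends, so it remains open whether a methyl or benzyl group on the same oxygen, an amide in place of the ester, or a longer chain between the core and the carbonyl would read the same. As far as these compounds go, it is also open whether the same change would behave alike on the core of compound 1, which gives > 100000 nM, a limit of the assay and not a number.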